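From chloro to trifluoromethyl at the limit of the assay

A few compounds are considered here, and "the series" means these few. Any claim that something is new, unique, unknown or untested is made for them only; others in the source may bear on it.

compound 1 `COc1ccc(-c2c(C)nc3c(N4CC[C@@H](NS(=O)(=O)c5ccc(NC(C)=O)cc5)C4)cc(C)nn23)cc1OC` gives > 95% (a limit)
compound 2 `COc1ccc(-c2c(C)nc3c(N4CC[C@@H](NS(=O)(=O)c5ccc(Cl)cc5)C4)cc(C)nn23)cc1OC` gives > 95% (a limit)

In an ADME assay on microsomes from liver (Mus musculus) for metabolic stability, read by LC-MS, with NADPH named in the record, with a stated time of 60 min, tested at 1 uM, in the absence of a further agent (on this read-out lower numbers stand for a less stable compound and higher numbers for a more stable compound), compound 2 gives > 95% and this is a limit, not a number. Within the data shown here, the series so far stands at the limit of > 95% in this assay, at which 2 of the 2 values shown sit, and offers no exact value as a reference point. The next compound is compound 3 `COc1ccc(-c2c(C)nc3c(N4CC[C@@H](NS(=O)(=O)c5ccc(C(F)(F)F)cc5)C4)cc(C)nn23)cc1OC` with trifluoromethyl in place of chloro on an aromatic carbon, para to a large group (trifluoromethyl in place of chloro on an aromatic carbon). Among the measured compounds shown here, the only measured step that bears on this is a step that the two limits leave unreadable from compound 1 to compound 2 and it offers no size to carry over. No step beyond the scatter is therefore expected in this assay and no direction can be given. The expected step is a number no higher from compound 2 to compound 3 (the limit leaves the size open) on present evidence. For compound 3 the estimate is 95% with an expected range of 82% to 100% in this read-out.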

Compound 3, percent of the compound remaining: > 95%
Compound 3 was reported as a limit (the forecaster's own chance of this, stated with the estimate: 65%); the middle value lies on the limit itself.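

No step can be read among compound 1, compound 2 and compound 3 in this assay because all three values are limits, not numbers: the limit of > 95% in this assay, at which 3 of the 3 values shown sit. The compounds shown leave open how far acetamido, chloro and trifluoromethyl differ in their stability, and whether any change at this aromatic carbon brings a value off the limit.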